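Swapping an acid for an amide chain on the shared core

This account rests on a few compounds, and the source may have more. Where it says the series, first, only, none or still open, it means among the compounds named here.

Three measured compounds share a core. Compound 1 `Cc1nc(-c2ccc(C(F)(F)F)cc2)sc1CNc1ccc(C(=O)O)cc1` carries a carboxy group on it; in a functional assay on CHO cells for agonist activity at Free fatty acid receptor 1 (Homo sapiens) (a lower number here means that less compound is needed, a higher number that more compound is needed for the effect), compound 1 gives < 10000 nM, which is a limit of the assay rather than a number. Compound 3 `Cc1nc(-c2ccc(C(F)(F)F)cc2)sc1CNc1ccc(CCC(=O)NC(C)C)cc1` bears a 2-(isopropylcarbamoyl)ethyl group in that place, and in this assay compound 3 gives 100 nM. The step that the limit leaves unreadable from compound 1 to compound 3 therefore has no readable size. Compound 2 `O=C(O)COc1ccc(NCc2cccc(Oc3ccccc3)c2)cc1` has a carboxymethoxy group on its core, and in this assay compound 2 gives 2040 nM, the highest of the two numbers shown, with compound 3 as its nearest neighbour at a much lower number. Compound 4 `O=C(CCc1ccc(NCc2cccc(Oc3ccccc3)c2)cc1)N1CCCC1` is the unmeasured counterpart of compound 2 with 2-((pyrrolidin-1-yl)carbonyl)ethyl in place of carboxymethoxy on an aromatic carbon. Within the data shown here, the only comparable step, from a carboxy group to a 2-(isopropylcarbamoyl)ethyl group, is the one from compound 1 to compound 3, and the limit hides how large it was; only its direction toward the number of compound 3 offers guidance. Compound 4 is therefore expected to need less compound than compound 2, a step of an 8.2-fold lower number from compound 2 to compound 4 (0.91 log units; beyond the scatter), giving an estimated 250 nM, with a range from 60 nM to 1000 nM.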

Compound 4, half-maximal effective concentration: 115 nM
For compound 4 the middle estimate is 2.2-fold (0.34 log units) above the measured one, and the stated range covers the measured number.
By their numbers in this assay, from the lowest: compounds 3 and 4 (each within the scatter of the next); then compound 2.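

On the core of compound 2, the step to a 2-((pyrrolidin-1-yl)carbonyl)ethyl group at this position, para to a large group, gives an 18-fold lower number from compound 2 to compound 4 (1.25 log units; beyond the scatter) in this assay. Among these compounds, this is the first readable size for a change of this kind, and it shows that on this core the number falls sharply when the carboxymethoxy group, with its carboxylic acid, gives way to an amide chain with no hydrogen-bond donor. The step from compound 1 to compound 3 still cannot be read, because compound 1 is reported only as a limit: the limit of < 10000 nM in this assay, at which 1 of the 4 values shown sits.

On these data alone, it remains open whether the drop comes from the amide or from the chain, which a 2-carboxyethyl group, a carboxylic acid on the same chain, would help to separate. As far as these compounds go, it is also open whether the ring matters, which a dimethylamide or a piperidine amide in this place would test.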